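Swapping bromo for chloro on the shared core

The source may hold more compounds than are shown below. What is called first, only, known or untested is meant among the compounds shown, and "the series" means these compounds.

Compound 1: `Nc1sc(Br)c(-c2cccc(C(F)(F)F)c2)c1C(=O)c1ccccc1` gives > 10 uM in a functional assay on CHO-K1 cells for agonist activity at adenosine receptor A1 (Homo sapiens), read by GTPgammaS binding; a lower number here means that less compound is needed, a higher number that more compound is needed for the effect.
Compound 2: `CCOC(=O)c1c(N)sc(-c2ccc(Cl)cc2)c1-c1cccc(C(F)(F)F)c1` gives 6.6 uM in this assay.

Compound 1 stands at a limit of this assay rather than at a number: the limit of > 10 uM in this assay, at which 1 of the 2 values shown sits. Because of that limit, all that is known for compound 1 is that more compound than the highest tested concentration would be needed, so its true position cannot be fixed on the scale. Among the measured compounds shown here, compound 2 is a different structure with an ester in place of the benzoyl group and a different arrangement of rings, so no single step connects it to compound 1, and its value only shows that a measurable number is reachable for this family.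

Compound 3 is `Nc1sc(Cl)c(-c2cccc(C(F)(F)F)c2)c1C(=O)c1ccccc1`. Its change from compound 1 is chloro in place of bromo on an aromatic carbon. For the measured compounds named here, no measured pair shows this kind of swap here, so the expectation rests on the small size of the change alone. The step from compound 1 to compound 3 is expected to be a step that the limit leaves unreadable from compound 1 to compound 3, not clearly beyond the scatter in either direction. Compound 3 is therefore estimated at 15 uM, with a range from 5 uM to 50 uM, and a real chance that this assay again reports only a limit.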

Compound 3, concentration for half-maximal effect: > 10 uM
Compound 3 was reported as a limit; the forecaster's own chance of this, stated with the estimate: 65%; the middle value lies beyond the limit too.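

In this assay compound 3 gives > 10 uM, which is a limit and not a number. Compound 1 stands at a limit too, so the swap of bromo for chloro between compound 1 and compound 3 gives no readable step: the limit of > 10 uM in this assay, at which 2 of the 3 values shown sit.

The compounds shown leave open whether bromo and chloro at this place on the shared core differ at all in this assay.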